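Working notes: methoxy for hydrogen, from compound 1 to compound 4

A few compounds are considered here, and "the series" means these few. Any claim that something is new, unique, unknown or untested is made for them only; others in the source may bear on it.

Compound 1 `CC1(C)Cc2c(ccc(C(=O)/C=C/c3ccccc3)c2OCc2ccccc2)O1` is the reference point of the series. In a functional assay on NCI-H460 cells (Homo sapiens) for antiproliferative activity, read by MTT assay, with a stated time of 48 h (on this read-out higher numbers stand for weaker inhibition and lower numbers for stronger inhibition), compound 1 returns only a limit of the assay, > 100000 nM. Compound 2 `CC1(C)Cc2c(OCc3ccccc3)ccc(C(=O)/C=C/c3ccc(Br)cc3)c2O1` also returns a limit in this assay, > 100000 nM. Compound 3 `COc1ccc(-c2nn(-c3ccccc3)cc2/C=C/C(=O)c2ccc3c(c2OCc2ccccc2)CC(C)(C)O3)cc1`, the largest member, returns a limit in this assay as well, > 100000 nM. Among the measured compounds shown here, no step between the measured compounds can be sized, since (the limit of > 100000 nM in this assay, at which 3 of the 3 values shown sit); compound 1 stands at that limit together with compound 2 and compound 3, and nothing sets it apart from either.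

Compound 4 `COc1ccc(/C=C/C(=O)c2ccc3c(c2OCc2ccccc2)CC(C)(C)O3)cc1` has not yet been measured. It differs from compound 1 by methoxy in place of hydrogen on an aromatic carbon; a methoxy enters where a hydrogen leaves, and the rest of the structure is kept. Given that compound 1 sits at > 100000 nM, the step of a number no higher from compound 1 to compound 4 (the limit leaves the size open) is expected to be none beyond the scatter, in neither direction. Compound 4 is accordingly estimated at 100000 nM, within 30000 nM to 300000 nM, and most probably reported again only as a limit.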

Compound 4, half-maximal inhibitory concentration: > 100000 nM
Compound 4: a limit, no number (the forecaster's own chance of this, stated with the estimate: 80%); the middle value sits exactly at the limit.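

No step can be read between compound 1 and compound 4 in this assay, since each returns only a limit: the limit of > 100000 nM in this assay, at which 4 of the 4 values shown sit.

The compounds shown leave open how far any of them lies beyond that limit, and whether methoxy in place of hydrogen changes activity at all.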